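A few compounds are considered here, and "the series" means these few. Any claim that something is new, unique, unknown or untested is made for them only; others in the source may bear on it.

Compound 1 `CC#CCN(C)Cc1cc2cc(O)ccc2n1C` gives 8800 nM in an assay on isolated protein for inhibition of Amine oxidase [flavin-containing] B (Rattus norvegicus); on this read-out higher numbers stand for weaker inhibition and lower numbers for stronger inhibition.
Compound 2 `C#CCNCc1cc2ccccc2n1C` gives 3830 nM in this assay.

Of these two numbers, compound 2 has the lower one, and the gap to compound 1 lies beyond the usual scatter of repeated measurements, so compound 2 is the stronger inhibitor of the pair. The next compound, compound 3 `C#CCN(Cc1ccccc1)Cc1cc2ccccc2n1C`, is made from compound 2 by a single change: benzyl in place of hydrogen on an amine nitrogen. Among the measured compounds shown here, no measured pair in this set shows this change, so its effect cannot be read off from the data at hand. The step is expected to go toward a lower number, that is toward stronger inhibition, of a size that goes somewhat beyond the scatter while staying moderate, so that the expected step is a 2.6-fold lower number from compound 2 to compound 3 (0.41 log units; beyond the scatter). Compound 3 is therefore expected to give about 1500 nM in this assay, with a likely range from 300 nM to 8000 nM.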

Compound 3, inhibition constant: 60000 nM
Estimate against measurement, compound 3: 40-fold (1.60 log units) below; measured number above the stated range.
By their numbers in this assay, from the lowest: compound 2; then compound 1; then compound 3.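

In this assay, putting benzyl in place of hydrogen on the amine nitrogen gives a 16-fold higher number from compound 2 to compound 3 (1.19 log units; beyond the scatter) and so costs much of the inhibition that compound 2 shows. Among the compounds shown here, this is the first direct view of this position, since no earlier pair differed in one place, and it shows that this nitrogen does not accept every group: here, the added benzyl goes with a large loss. Nothing available here gives a reason for this loss.

Going by these compounds, it remains open whether the loss belongs to the aromatic ring of benzyl or would come with any larger group on this nitrogen, and an ethyl or cyclohexylmethyl group in the same place would help to separate the two. On these data alone, as this is a single pair, it also remains open whether the change would have the same effect on a different core.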